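From a Cyanophenyl to a Methylpyridinyl Group

The compounds below may be only part of what the source reports. "The series", "measured", "known", "first", "only" and "open" are said of these compounds alone.

Compound 1 `CN(C)C(=O)c1cccnc1NCCCN1CCN(c2ccccc2C#N)CC1`: 2 nM
Compound 2 `CN(C)C(=O)c1cccnc1NCCCN1CCN(c2ccccc2-c2ncco2)CC1`: 0.316 nM

In a functional assay for antagonist activity at Alpha-1A adrenergic receptor (Oryctolagus cuniculus) (on this read-out higher numbers stand for weaker binding and lower numbers for tighter binding), compound 1 gives 2 nM, the higher of the two measured numbers. Compound 2 gives 0.316 nM. Within the data shown here, the only measured step, a 6.3-fold lower number from compound 1 to compound 2 (0.80 log units; beyond the scatter), comes from 1,3-oxazol-2-yl in place of cyano on an aromatic carbon.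

Compound 3 `Cc1cnccc1N1CCN(CCCNc2ncccc2C(=O)N(C)C)CC1` carries 3-methylpyridin-4-yl in place of 2-cyanophenyl on an amine nitrogen in a ring. Among the measured compounds shown here, no measured step covers this exchange: the one known step alters the same group, but in a different way, so it gives little guidance. Compound 3 is expected to give roughly 6 nM, within 1.5 nM to 30 nM. This estimate means a 3.0-fold higher number from compound 1 to compound 3 (0.48 log units; beyond the scatter), with considerable uncertainty.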

Compound 3, dissociation constant: 200 nM
Estimate against measurement, compound 3: 33-fold (1.52 log units) below; measured number above the stated range.
By their numbers in this assay, from the lowest: compound 2; then compound 1; then compound 3.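

In this assay, the group on the amine nitrogen of the six-membered ring is far from interchangeable: 3-methylpyridin-4-yl in place of 2-cyanophenyl gives a 100-fold higher number from compound 1 to compound 3 (2.00 log units; beyond the scatter), a large step. The aromatic ring here can therefore move the number upward as well as downward, opposite in direction to a 6.3-fold lower number from compound 1 to compound 2 (0.80 log units; beyond the scatter). Nothing available accounts for this rise.

From the compounds shown here alone, the exchange alters the ring atoms and the substituent together, so their separate shares remain open. A 2-methylphenyl or an unsubstituted pyridin-4-yl group on that nitrogen would separate them.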